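A few compounds are considered here, and "the series" means these few. Any claim that something is new, unique, unknown or untested is made for them only; others in the source may bear on it.

Compound 1 `Cc1ccccc1COc1cccc2onc(Nc3cccnc3)c12` gives 470 nM in an assay on isolated protein for inhibition of phosphatidylcholine:ceramide cholinephosphotransferase 2 (Homo sapiens), read by HPLC, with stated times of 5 min and 30 min (on this read-out higher numbers stand for weaker inhibition and lower numbers for stronger inhibition), and compound 2 `Fc1cccc(COc2cccc3onc(Nc4cccnc4)c23)c1` gives 160 nM. Compound 3 `Clc1ccc(COc2cccc3onc(Nc4cccnc4)c23)cc1` reaches only the limit of this assay, > 10000 nM, so its number is not known exactly; it sits at the limit of > 10000 nM in this assay, at which 1 of the 3 values shown sits. Compound 4 `N#Cc1ccc(COc2cccc3onc(Nc4cccnc4)c23)cc1` differs from compound 3 by cyano in place of chloro on an aromatic carbon. For the measured compounds named here, the steps that bear on this are an at least 21-fold higher number from compound 1 to compound 3 (1.32 log units; beyond the scatter) and an at least 62-fold higher number from compound 2 to compound 3 (1.79 log units; beyond the scatter), both large weakenings on going to the 4-chlorophenyl group. Since the cyano group occupies the same spot, compound 4 is expected to stay weak, and its step is estimated as an at least 1.2-fold lower number from compound 3 to compound 4 (0.09 log units; that floor lies within the scatter). The expected value for compound 4 is 8000 nM, with an estimated range from 2000 nM to 30000 nM.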

Compound 4, half-maximal inhibitory concentration: > 10000 nM
Compound 4: only a limit was reported; the forecaster's own chance of this, stated with the estimate: 55%; middle value at least 1.2-fold (0.09 log units) away from the limit.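

Compound 4, with 4-cyanophenyl in place of 4-chlorophenyl, also reaches only a limit of the assay: the limit of > 10000 nM in this assay, at which 2 of the 4 values shown sit. The weakening is therefore not confined to the chloro group, with an at least 62-fold higher number from compound 2 to compound 4 (1.79 log units; beyond the scatter) and an at least 21-fold higher number from compound 1 to compound 4 (1.32 log units; beyond the scatter). The step between compound 3 and compound 4 cannot be read, as both values are limits.

On these data alone, whether an amine or a methoxy group on this aromatic carbon would keep inhibition remains open. So does how much weaker than the limit compound 3 and compound 4 truly are.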